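Methyl for Phenyl on a Spiro-Fused Pyrazole Nitrogen

A few compounds are considered here, and "the series" means these few. Any claim that something is new, unique, unknown or untested is made for them only; others in the source may bear on it.

Measured compounds:
- compound 1, `Cn1ncc2c1CC(O)OC21CCN(Cc2ccccc2)CC1`: 190 nM
- compound 2, `c1ccc(CN2CCC3(CC2)OCCc2c3cnn2-c2ccccc2)cc1`: 1.71 nM

Among the measured compounds shown here, in an assay for displacement of a labelled ligand from Sigma non-opioid intracellular receptor 1 (Cavia porcellus), read by scintillation counting, with a stated time of 180 min (a lower number here means a stronger inhibitor, a higher number a weaker inhibitor), compound 2 gives 1.71 nM, the lowest of the two numbers known here. For the measured compounds named here, the only other measured compound, compound 1, gives 190 nM in this assay, a gap well beyond the usual scatter. Compound 3, `Cn1ncc2c1CCOC21CCN(Cc2ccccc2)CC1`, has not yet been measured. It differs from compound 2 in one place: methyl in place of phenyl on an aromatic nitrogen. Going by the values given here, no measured pair shows this exact change on its own. Compound 1 also carries a methyl on that nitrogen but differs from compound 3 in a further place, so it sets only a rough upper bound for the number. The step from compound 2 to compound 3 is expected to raise the number in this assay, by an amount beyond the scatter, a 23-fold higher number from compound 2 to compound 3 (1.37 log units; beyond the scatter). Compound 3 is therefore estimated at 40 nM, within a range of 8 nM to 200 nM.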

Compound 3, inhibition constant: 9.2 nM
For compound 3 the middle estimate is 4.3-fold (0.64 log units) above the measured one; the measured number falls inside the stated range.
By their numbers in this assay, from the lowest: compound 2; then compound 3; then compound 1.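

In this assay, the change at this position alone gives a 5.4-fold higher number from compound 2 to compound 3 (0.73 log units; beyond the scatter) and so costs some strength, but the step is only modest: the much smaller methyl still works on this aromatic nitrogen, and phenyl is not essential there. Compound 3 also allows compound 1 to be read properly, since a 21-fold lower number from compound 1 to compound 3 (1.31 log units; beyond the scatter) is a large step that comes from hydrogen in place of hydroxy on a saturated ring carbon, so the high number of compound 1 says little about methyl on the nitrogen itself. Nothing available here explains why either change has the size it does.

Phenyl and methyl are the only groups shown on this nitrogen, so it remains open where an ethyl, a benzyl or a chain ending in an amine would fall. From the compounds shown here alone, whether the hydroxy carries the same penalty when phenyl sits on the nitrogen also remains open.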